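From ethoxy to (methylsulfonyl)oxy in compound 3

The source may hold more compounds than are shown below. What is called first, only, known or untested is meant among the compounds shown, and "the series" means these compounds.

In a functional assay on A549 cells (Homo sapiens) for cytotoxicity (a higher number here means that more compound is needed for the effect, a lower number that less compound is needed), compound 1 (`CCOc1cc(-c2ccccc2)nc2ccccc12`) stands at > 10 ug/mL as a limit of the assay and not a number. Compound 2 (`COc1ccc2nc(-c3ccccc3)cc(O)c2c1`) reads 0.19 ug/mL in this assay as a measured number. Compound 3 (`CS(=O)(=O)Oc1cc(-c2ccccc2)nc2ccccc12`) carries methylsulfonyl in place of ethyl on an oxygen on an aromatic ring and has yet to be measured. Among the measured compounds shown here, no measured step covers this change, so only a modest move towards lower concentrations in this assay is expected (an at least 1.6-fold lower number from compound 1 to compound 3 (0.22 log units; that floor lies within the scatter)) for now. For compound 3 the estimated value is 6 ug/mL (expected range 1 ug/mL to 20 ug/mL) and a reading at the limit remains possible.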

Compound 3, half-maximal effective concentration: 6.21 ug/mL
For compound 3 the middle estimate is 1.0-fold (0.01 log units) below the measured one; low and high end bracket the measured number.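

Compound 3 gives a measured number at this oxygen on an aromatic ring, where compound 1 offered only a limit of the assay. In this assay, putting methylsulfonyl in place of ethyl gives an at least 1.6-fold lower number from compound 1 to compound 3 (0.20 log units; that floor lies within the scatter), so the change can be read only as a floor. On these data alone, the full size of the step stays unknown because compound 1 sits at a limit: the limit of > 10 ug/mL in this assay, at which 1 of the 3 values shown sits. The compounds shown leave open whether a longer chain on the sulfonyl, such as ethylsulfonyl, or an amine-bearing chain on this oxygen would read differently.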